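The compounds below may be only part of what the source reports. "The series", "measured", "known", "first", "only" and "open" are said of these compounds alone.

Compound 1, `O=C1N/C(=N/c2csc(-c3ccc(Cl)cc3)c2)S/C1=C\c1ccc(Br)cc1`, gives 3300 nM in a functional assay on HCT-116 cells (Homo sapiens) for cytotoxicity, read by MTT assay, with a stated time of 72 h; on this read-out higher numbers stand for weaker inhibition and lower numbers for stronger inhibition.
Compound 2, `O=C1N/C(=N/c2csc(-c3ccc(Cl)cc3)c2)S/C1=C\c1ccc(O)cc1`, gives "not determined" (no result reported) in this assay.

Both compounds share the same core and differ only in the ring hanging from the double-bonded chain carbon. Compound 1 carries a brominated phenyl ring there, while compound 2 carries a hydroxylated one; for compound 2 no number was reported in this assay, so where it stands among these compounds cannot be said from the data. Among the measured compounds shown here, the only anchor is compound 1, which reaches a half-maximal inhibitory concentration in the low micromolar region.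

Compound 3, `O=C1N/C(=N/c2csc(-c3ccc(Cl)cc3)c2)S/C1=C\c1ccc2ccccc2c1`, has yet to be measured. Relative to compound 2 the change is naphthalen-2-yl in place of 4-hydroxyphenyl on a double-bonded chain carbon bound to a double-bonded ring carbon. Since compound 2 has no value, the size of the step cannot be anchored from that side; the expectation is that compound 3 lands in the same broad region as compound 1, without a clear direction beyond the usual scatter. Compound 3 is therefore estimated at 3000 nM in this assay, with a plausible range from 700 nM to 13000 nM, because compound 1 gives 3300 nM on the same core.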

Compound 3, half-maximal inhibitory concentration: 3000 nM
Estimate against measurement, compound 3: no gap at the digits printed; the measured number falls inside the stated range.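

In this assay, putting naphthalen-2-yl in place of 4-bromophenyl on a double-bonded chain carbon bound to a double-bonded ring carbon gives a 1.1-fold lower number from compound 1 to compound 3 (0.04 log units; within the scatter), so the two compounds cannot be told apart. Among the compounds shown here, this is the first sign of how this position responds to a change of group: the single brominated ring and the two six-membered aromatic rings of naphthalen-2-yl give values that read the same, even though the new group carries no bromine and has a second ring. Nothing measured here explains why these two groups read alike.

On these data alone, compound 2 has no number, so the steps that involve it cannot be read, and what a hydroxyl group on the ring does at this position stays unknown. Also open, as far as these compounds go, is whether a phenyl ring carrying an amine or a carboxylic acid, or a longer chain in place of the ring, would stay in the region of compound 1 at 3300 nM or move clearly away from it.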